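This account rests on a few compounds, and the source may have more. Where it says the series, first, only, none or still open, it means among the compounds named here.

Compound 1, with the structure `CC(C)(C)N(NC(=O)c1ccccc1)C(=O)c1ccccc1Cl`, serves as the reference point. In an assay on cells for agonist activity at ecdysone receptor (Bombyx mori), read by a luciferase reporter, with a stated time of 24 h (a lower number here means that less compound is needed, a higher number that more compound is needed for the effect), compound 1 gives 75.9 nM. Compound 2, `CC(C)(C)N(NC(=O)c1ccccc1)C(=O)c1ccccc1Br`, carries bromo in place of chloro on an aromatic carbon; this produces a 2.2-fold higher number from compound 1 to compound 2 (0.35 log units; beyond the scatter). Compound 3, `CC(C)(C)N(NC(=O)c1ccc(Cl)cc1)C(=O)c1ccccc1Cl`, differs from compound 1 by chloro in place of hydrogen on an aromatic carbon, and in this assay compound 3 gives 115 nM, which is a 1.5-fold higher number from compound 1 to compound 3 (0.18 log units; within the scatter). In this assay compound 2 gives 170 nM.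

Compound 4, `CC(C)(C)N(NC(=O)c1ccc(Br)cc1)C(=O)c1ccccc1Cl`, is not yet measured. It differs from compound 3 by bromo in place of chloro on an aromatic carbon. For the measured compounds named here, this is the same kind of change as the one from compound 1 to compound 2, but not the same: there the bromo sits ortho to a large group, here it sits para to a large group, on the other ring. Going by the values given here, the only measured precedent for exchanging chloro for bromo is the step of a 2.2-fold higher number from compound 1 to compound 2 (0.35 log units; beyond the scatter). On that basis a modest rise in the number is expected for compound 4, something like a 1.6-fold higher number from compound 3 to compound 4 (0.19 log units; within the scatter), with the caveat that the surroundings of the change differ. The estimate for compound 4 in this assay is therefore 180 nM, expected to fall between 85 nM and 380 nM.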

Compound 4, half-maximal effective concentration: 33.9 nM
Compound 4: middle estimate off by 5.3-fold (0.73 log units), on the high side; the whole stated range lies above it.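

In this assay, the exchange of chloro for bromo in the 4-chlorophenyl group gives a 3.4-fold lower number from compound 3 to compound 4 (0.53 log units; beyond the scatter), and bromo in place of hydrogen at that same place gives a 2.2-fold lower number from compound 1 to compound 4 (0.35 log units; beyond the scatter). The exchange of chloro for bromo thus does not carry over from one core to the other in this series, not even in direction: the same change on two cores in this assay, a 2.2-fold higher number (0.35 log units; beyond the scatter) from compound 1 to compound 2 and a 3.4-fold lower number (0.53 log units; beyond the scatter) from compound 3 to compound 4, 7.6-fold (0.88 log units) apart, beyond the scatter of two such steps. With only these two exchanges, which stand at different places on different rings, the data do not show why they diverge, and they give no rule for any further core.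

The compounds shown leave open whether a methyl, methoxy or trifluoromethyl group para to a large group would read more like chloro or like bromo in this assay. They also leave open whether the result for bromo would hold if the other ring carried a nitrile or an amine in place of its chloro.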